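Dropping a Fluoro Group: What to Expect for Compound 4

The source may report more compounds than this note shows. Statements on the series, on what has been measured and on what is new or still open speak of the compounds shown alone.

Three compounds have numbers in a functional assay on PC-3 cells (Homo sapiens) for cytotoxicity, read by MTT assay, with a stated time of 72 h; a lower number here means a stronger inhibitor of growth, a higher number a weaker inhibitor of growth. Compound 1 `CCCCOC(=O)Nc1ccc([Se]C#N)cc1` gives 40800 nM. Compound 2 `CCCCCCOC(=O)Nc1ccc([Se][Se]c2ccc(NC(=O)OCCCCCC)cc2)cc1` gives 25700 nM. Compound 3 `N#C[Se]c1ccc(NC(=O)Oc2ccc(F)cc2)cc1` gives 40400 nM. Among these three numbers compound 3 stands second highest; its nearest neighbour is compound 1, whose number lies within the scatter of repeated measurements, and its furthest is compound 2, whose number also lies within that scatter. The three measured compounds therefore cannot be told apart by this assay.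

Compound 4 `N#C[Se]c1ccc(NC(=O)Oc2ccccc2)cc1` has not yet been measured. It differs from compound 3 in one place: hydrogen in place of fluoro on an aromatic carbon. Among the measured compounds shown here, no step between two measured compounds of this kind is available to guide the forecast, so the expectation rests on the change itself, the loss of the fluoro group. Such a change is expected to move the number in this assay by no more than the scatter, in no particular direction. The step from compound 3 to compound 4 is accordingly estimated as a 1.0-fold lower number from compound 3 to compound 4 (0.00 log units; within the scatter). For compound 4 the expected value in this assay is 40000 nM, with a likely range from 20000 nM to 80000 nM.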

Compound 4, concentration for total growth inhibition: 37500 nM
Compound 4: middle estimate off by 1.1-fold (0.03 log units), on the high side, and the stated range covers the measured number.
By their numbers in this assay, from the lowest: compounds 2, 4, 3 and 1 (each within the scatter of the next).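

In this assay, among the compounds shown here, compounds 3 and 4 give the first direct reading of this change, hydrogen in place of fluoro on an aromatic carbon para to a large group (a 1.1-fold lower number from compound 3 to compound 4 (0.03 log units; within the scatter)), and this step stays within the scatter, so the two compounds cannot be told apart at this place. The new compound also gives a second single-place comparison, phenyl in place of butyl on an oxygen next to a carbonyl group (a 1.1-fold lower number from compound 1 to compound 4 (0.04 log units; within the scatter)), and this step also stays within the scatter, so compounds 1 and 4 cannot be told apart either. Nothing shown here offers an explanation for either result.

Both readings come from a single assay and cover only these few groups, so neither step says how a chloro, methoxy or amine group on the same aromatic carbon would compare with compound 4. From the compounds shown here alone, it also remains open whether a longer chain or a benzyl group on the oxygen next to the carbonyl group would give a number that stands clear of the scatter around compound 4.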